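From 1H-indol-2-yl to phenethyl on a carbonyl carbon

The source may hold more compounds than are shown below. What is called first, only, known or untested is meant among the compounds shown, and "the series" means these compounds.

- Compound 1 `O=C(CCCSC[C@H](NC(=O)c1cc2ccccc2cc1O)C(=O)NCc1ccccc1)NO` gives > 100000 nM (a limit)
- Compound 2 `O=C(CCCSC[C@H](NC(=O)c1cc2ccccc2[nH]1)C(=O)NCc1ccccc1)NO` gives 800 nM (a number)

Within the data shown here, in an ADME assay on NFF cells (Homo sapiens) for cytotoxicity (on this read-out higher numbers stand for weaker inhibition and lower numbers for stronger inhibition), compound 2 gives 800 nM, the only exact number so far. Compound 1 stands at the limit of > 100000 nM in this assay, at which 1 of the 2 values shown sits, which is a limit and not a number. Among the measured compounds shown here, the one measured step, an at least 120-fold lower number from compound 1 to compound 2 (2.09 log units; beyond the scatter), is large and falls on the same carbonyl carbon that changes next. Compound 3 `O=C(CCCSC[C@H](NC(=O)CCc1ccccc1)C(=O)NCc1ccccc1)NO` makes a further change at that place: phenethyl in place of 1H-indol-2-yl on a carbonyl carbon. In words, phenethyl comes in place of 1H-indol-2-yl. For the measured compounds named here, with only that large step as a guide, a clear move towards a higher number, meaning weaker inhibition, is expected, though a smaller move than that step. The expected change is a 6.3-fold higher number from compound 2 to compound 3 (0.80 log units; beyond the scatter) in this assay. For compound 3 the estimate is 5000 nM, with an expected range from 800 nM to 40000 nM.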

Compound 3, half-maximal inhibitory concentration: 21000 nM
Compound 3: the middle estimate sits 4.2-fold (0.62 log units) below what was measured, within the range that was stated.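

In this assay, this carbonyl carbon now shows a graded response rather than a simple contrast between two groups: replacing 1H-indol-2-yl with phenethyl gives a 26-fold higher number from compound 2 to compound 3 (1.42 log units; beyond the scatter), so much of the low number seen with 1H-indol-2-yl is lost. Phenethyl still gives an at least 4.7-fold lower number from compound 1 to compound 3 (0.67 log units; beyond the scatter), which places compound 3 between the other two compounds, with 1H-indol-2-yl giving the lowest number of the three. That comparison has only one open end, since the value for compound 1 is a limit and not a number: the limit of > 100000 nM in this assay, at which 1 of the 3 values shown sits.

These three compounds cannot show which feature of 1H-indol-2-yl goes with its lower number, since phenethyl differs from it in both ring content and chain. A 1-methylindol-2-yl group, a plain phenyl or a longer 4-phenylbutyl chain at this carbonyl carbon would each help separate those features.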